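The source may hold more compounds than are shown below. What is called first, only, known or untested is meant among the compounds shown, and "the series" means these compounds.

In a functional assay on MCF7 cells (Homo sapiens) for cytotoxicity, read by MTT assay, with a stated time of 48 h (on this read-out higher numbers stand for weaker inhibition and lower numbers for stronger inhibition), compound 1 `O=C1Nc2ccccc2C1(c1c[nH]c2ccccc12)c1c[nH]c2ccccc12` gives 49800 nM and compound 2 `COc1ccc2[nH]cc(C3(c4c[nH]c5ccc(OC)cc45)C(=O)Nc4ccccc43)c2c1` gives 33600 nM. These two values lie within the usual scatter of each other, so the numbers do not separate compound 1 from its only measured companion. Compound 3 `O=C1Nc2ccc(F)cc2C1(c1c[nH]c2ccccc12)c1c[nH]c2ccccc12` keeps the core of compound 1 and carries a single change: fluoro in place of hydrogen on an aromatic carbon, on a six-membered aromatic ring of carbon only that is part of a fused or bridged system of two rings (fluoro in place of hydrogen on an aromatic carbon). Among the compounds with values here, no two measured compounds differ in one place, so the data offer no direct precedent for this change. Within the data shown here, the only guide is that compound 2 at 33600 nM stays within the scatter of compound 1 at 49800 nM. In this assay, no step beyond the scatter is therefore expected, in either direction. The estimated step of a 1.3-fold lower number from compound 1 to compound 3 (0.12 log units; within the scatter) is expected to remain that small. For compound 3 the expected value is 38000 nM, with an estimated range from 15000 nM to 85000 nM.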

Compound 3, half-maximal inhibitory concentration: 23600 nM
The estimate for compound 3 lay 1.6-fold (0.21 log units) above the measured number; measured number inside the range.
By their numbers in this assay, from the lowest: compounds 3, 2 and 1 (each within the scatter of the next, the first and the last beyond it).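

In this assay, within the data shown here, adding the fluoro group gives a 2.1-fold lower number from compound 1 to compound 3 (0.32 log units; beyond the scatter) and so provides the first readable single-place step, a modest one. Among these compounds, it shows that on this six-membered aromatic ring of carbon only, part of a fused or bridged system of two rings, a fluoro group meta to a fused ring and para to a fused ring is accepted with a lower number and not a higher one, which the earlier compounds could not show because they differ from each other in more than one place. Nothing measured on these compounds bears on what lies behind this step.

From the compounds shown here alone, whether the lower number is particular to fluoro or would also appear with another group at this place, such as chloro, methoxy, nitrile or an amine, remains open, as does whether fluoro would give a step of similar size elsewhere on the same ring. Also open, going by these compounds, is how the fluoro group would combine with the methoxy groups carried by compound 2.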